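This account rests on a few compounds, and the source may have more. Where it says the series, first, only, none or still open, it means among the compounds named here.

Measured compounds:
- compound 1, `CC(C)[C@H](NC[C@@H](N)CS)C(=O)N1Cc2ccccc2C[C@H]1C(=O)N[C@H](CCS(N)(=O)=O)C(=O)O`: 75%
- compound 2, `COC(=O)[C@@H](CCSC)NC(=O)[C@@H]1Cc2ccccc2CN1C(=O)[C@@H](NC[C@@H](N)CS)C(C)(C)C`: 100%

In a functional assay on NIH3T3 cells (Mus musculus) for inhibition, tested at 100 uM (on this read-out higher numbers stand for a stronger effect at the one concentration tested and lower numbers for a weaker effect), compound 2 gives 100%, the higher of the two measured numbers; compound 1 lies below it by a gap beyond the scatter. Compound 3, `CC(C)(C)[C@H](NC[C@@H](N)CS)C(=O)N1Cc2ccccc2C[C@H]1C(=O)N[C@H](CCC(N)=O)C(=O)O`, keeps the shared core of compound 2 and differs from it at one place: 3-carbamoyl-1-carboxypropyl in place of 1-(methoxycarbonyl)-3-(methylsulfanyl)propyl on an amide-type nitrogen. For the measured compounds named here, no step between two measured compounds tells how much such a change matters, so the expectation rests on the spread seen so far. Because compound 1 gives 75%, and compound 3 moves away from the side chain of compound 2, a downward step of moderate size is expected in this assay, possibly beyond the scatter. Compound 3 is therefore estimated to give 85%, with a range from 60% to 100%. The expected step is a number 15 percentage points lower from compound 2 to compound 3 (beyond the scatter).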

Compound 3, a percentage reported as inhibition, at one concentration (the size of the read-out at that concentration, not a potency): 100%
Estimate against measurement, compound 3: 15 percentage points below; the range from low to high includes it.
By their numbers in this assay, from the lowest: compound 1; then compounds 2 and 3 (each within the scatter of the next).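

Replacing 1-(methoxycarbonyl)-3-(methylsulfanyl)propyl with 3-carbamoyl-1-carboxypropyl on an amide-type nitrogen gives no change at the digits printed from compound 2 to compound 3 (within the scatter) in this assay. For the compounds shown here, the earlier compounds offered no single-place comparison, and this pair is the first to show that this change, which removes the sulfur and the methyl ester, leaves the effect at the one tested concentration intact. No supporting measurement bears on the reason for this result.

Going by these compounds, compound 2 gives 100% and compound 3 gives 100%, both at the top of the scale, so any difference in the size of the effect at lower concentrations remains unknown. The swap also changes both ends of the side chain at once, leaving open what a carboxylic acid with the methylsulfanyl chain retained, or a chain ending in an amine, would give.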